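The source may hold more compounds than are shown below. What is called first, only, known or untested is meant among the compounds shown, and "the series" means these compounds.

Measured compounds in an ADME assay on HeLa cells (Homo sapiens) for cytotoxicity, read by XTT assay, with a stated time of 3 days; a lower number here means that less compound is tolerated, a higher number that more compound is tolerated:
Compound 1 `C1=C(/C=C/c2ccccn2)COc2ccccc21` gives > 50000 nM, a limit of the assay rather than a number.
Compound 2 `C1=C(/C=C/c2cccnc2)COc2ccccc21` gives 75000 nM.
Compound 3 `C1=C(/C=C/c2ccncc2)COc2ccccc21` gives 75000 nM.

Compound 2 stands level with compound 3 at the digits printed: the step of no change at the digits printed from compound 2 to compound 3 (within the scatter) lies within the scatter. The steps a step that the limit leaves unreadable from compound 1 to compound 2 and a step that the limit leaves unreadable from compound 1 to compound 3 cannot be sized because the limit of > 50000 nM in this assay, at which 1 of the 3 values shown sits, hides the starting point.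

Compound 4 `C1=C(/C=C\c2cccnc2)COc2ccccc21` is the unmeasured target. Compared with compound 2, (the two compounds have the same atoms and bonds and differ only in configuration as drawn: 1 of 1 stereo elements differ; a double bond is drawn E in compound 2 and Z in compound 4). For the measured compounds named here, none of the measured steps changes a double-bond configuration; they all swap the pyridinyl attachment, and the one readable step shows no change. On that basis compound 4 is expected to tolerate about as much compound as compound 2, with a step of no change at the digits printed from compound 2 to compound 4 (within the scatter) that is expected to stay within the scatter. The estimate for compound 4 in this assay is 75000 nM, expected between 35000 nM and 150000 nM.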

Compound 4, half-maximal cytotoxic concentration: 37500 nM
For compound 4 the middle estimate is 2.0-fold (0.30 log units) above the measured one; measured number inside the range.
By their numbers in this assay, from the lowest: compounds 4, 2 and 3 (each within the scatter of the next).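

In this assay, redrawing the chain double bond from E to Z with pyridin-3-yl kept in place gives a 2.0-fold lower number from compound 2 to compound 4 (0.30 log units; within the scatter). The earlier steps shown here only swapped the pyridinyl attachment, so they said nothing about the configuration of this double bond. This step isolates that configuration alone, with nothing else in the structure altered: the fact that compounds 2 and 4 differ only in the configuration as drawn

Still open, as far as these compounds go, is whether the Z configuration gives the same picture with pyridin-2-yl or pyridin-4-yl. Also open, from the compounds shown here alone, is how an amine or a carboxylic acid added to the shared core would read in this assay.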